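Anomeric configuration change on the shared core: compound 4

The source may hold more compounds than are shown below. What is called first, only, known or untested is meant among the compounds shown, and "the series" means these compounds.

Measured compounds in a functional assay on MDA-MB-231 cells (Homo sapiens) for cytotoxicity, read by MTT assay, with a stated time of 48 h; on this read-out lower numbers stand for an effect already at smaller amounts and higher numbers for an effect only at larger amounts of compound:
compound 1 `CO[C@H]1O[C@H](COc2ccc(OC3CCCCC3)cc2)[C@@H](O)[C@H](O)[C@H]1Oc1ccc(C(C)C)cc1` gives 25000 nM
compound 2 `CO[C@H]1O[C@H](COc2ccc(OC3CCCCC3)cc2)[C@@H](O)[C@H](O)[C@H]1Oc1ccc(OC2CCCCC2)cc1` gives 20000 nM
compound 3 `CO[C@H]1O[C@H](COc2ccc(-c3ccccc3)cc2)[C@@H](O)[C@H](O)[C@H]1Oc1ccc(C(C)C)cc1` gives 31000 nM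

Compound 1 stands second highest of the three numbers. Its nearest neighbour is compound 3, at a 1.2-fold higher number from compound 1 to compound 3 (0.09 log units; within the scatter), and its furthest is compound 2, at a 1.3-fold lower number from compound 1 to compound 2 (0.10 log units; within the scatter); both of these lie within the scatter, so the three measured compounds cannot be told apart on this read-out.

Compound 4 `CO[C@@H]1O[C@H](COc2ccc(OC3CCCCC3)cc2)[C@@H](O)[C@H](O)[C@H]1Oc1ccc(C(C)C)cc1` is the new entry. Its difference from compound 1: the two compounds have the same atoms and bonds and differ only in configuration as drawn: 1 of 5 stereo elements differ; a stereocentre at a saturated ring carbon is drawn S in compound 1 and R in compound 4. Nothing leaves and nothing enters; the change sits at the stereocentre at a saturated ring carbon of the shared core.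

Neither measured step bears on a configuration change. Both steps recorded so far, a 1.3-fold lower number from compound 1 to compound 2 (0.10 log units; within the scatter) and a 1.2-fold higher number from compound 1 to compound 3 (0.09 log units; within the scatter), replace one group on an aromatic carbon with another and stay within the scatter. Within the data shown here, there is no measured pair in which only configuration differs, so the direction of any effect cannot be read from the data. The working expectation is therefore a step of no change at the digits printed from compound 1 to compound 4 (within the scatter), that is, none beyond the scatter, with the range widened for the untested type of change. Compound 4 is expected to give 25000 nM, estimated between 9000 nM and 70000 nM in this assay.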

Compound 4, half-maximal effective concentration: 35000 nM
Beside the measured number, compound 4's estimate is 1.4-fold (0.15 log units) below it; the measured number falls inside the stated range.
By their numbers in this assay, from the lowest: compounds 2, 1, 3 and 4 (each within the scatter of the next).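

Compound 4 supplies the first pair on this series that tests configuration on its own, at the stereocentre at a saturated ring carbon of the shared core, and the comparison isolates that single stereo element: the fact that compounds 1 and 4 differ only in the configuration as drawn

In this assay, the switch from S to R as drawn gives a 1.4-fold higher number from compound 1 to compound 4 (0.15 log units; within the scatter), so no effect of configuration at this position can be read on this read-out for this pair of substituents. Among these compounds, the configuration change therefore stands with the two replacements on an aromatic carbon as a step that does not separate the compounds, and this position, in either drawn configuration, offers no handle on the number so far.

The compounds shown leave open whether this holds when the same stereocentre is drawn R with the groups of compound 2 or compound 3, since each of those appears here only as drawn S. They also leave open whether any group of a different kind on an aromatic carbon, such as an amine or a carboxylic acid, would produce a step beyond the scatter in this assay.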